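Longer Chains in a Small Cytotoxicity Series

This account rests on a few compounds, and the source may have more. Where it says the series, first, only, none or still open, it means among the compounds named here.

Three compounds have been measured in a functional assay on MGC-803 cells (Homo sapiens) for cytotoxicity, read by MTT assay, with a stated time of 72 h; a lower number here means a stronger inhibitor, a higher number a weaker inhibitor:
compound 1 `CCSC(=S)N[C@H]1CCOC1=O` gives > 128000 nM
compound 2 `CCCCSC(=S)N[C@H]1CCOC1=O` gives > 128000 nM
compound 3 `CCCCCCCCCCCCSC(=S)N[C@H]1CCOC1=O` gives 33300 nM

The value of compound 1 is a limit of this assay, not a number. The value of compound 2 is likewise a limit. The change from compound 1 to compound 2, (ethyl in place of hydrogen on a saturated chain carbon, two bonds along the chain from a sulfur), therefore gives a step that the two limits leave unreadable from compound 1 to compound 2 because of the limit of > 128000 nM in this assay, at which 2 of the 3 values shown sit. Compound 3 alone yields a number, and how compound 3 differs from compound 1 is not broken down here.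

Compound 4, `CCCCCCCCCCCCCCSC(=S)N[C@H]1CCOC1=O`, is not yet measured. It differs from compound 3 by ethyl in place of hydrogen on a saturated chain carbon, ten or more bonds along the chain from a sulfur. This is the same kind of change as from compound 1 to compound 2, but here it sits at a different place along the chain from a sulfur. With the earlier step unreadable, the expectation rests on compound 3 and its value 33300 nM alone. Compound 4 is expected to give 25000 nM, estimated between 8000 nM and 80000 nM, with the step expected to be a 1.3-fold lower number from compound 3 to compound 4 (0.12 log units; within the scatter).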

Compound 4, half-maximal inhibitory concentration: 36600 nM
For compound 4 the middle estimate is 1.5-fold (0.17 log units) below the measured one; the measured number falls inside the stated range.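

In this assay, ethyl in place of hydrogen on a saturated chain carbon, ten or more bonds along the chain from a sulfur, gives a 1.1-fold higher number from compound 3 to compound 4 (0.04 log units; within the scatter), so at this place the change stays within the usual scatter of repeated measurements. The same kind of change two bonds along the chain from a sulfur, from compound 1 to compound 2, cannot be read because both values are limits of the assay, not numbers: the limit of > 128000 nM in this assay, at which 2 of the 4 values shown sit. All four compounds share one core, so these results show nothing about how the change behaves on another core.

Going by these compounds, whether a longer chain, or a chain carrying an amine, would give a different number stays open. Also open, on these data alone, is how chains between those of compound 2 and compound 3 would read.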